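This account rests on a few compounds, and the source may have more. Where it says the series, first, only, none or still open, it means among the compounds named here.

Compound 2 `CN(C)CCCCOc1cccc2ccccc12` gives 470 nM in a functional assay for agonist activity at 5-hydroxytryptamine receptor 1B (Homo sapiens) (a higher number here means a weaker inhibitor, a lower number a stronger inhibitor), the upper end of the two numbers measured, though the gap to compound 1 `NCCCOc1cccc2ccccc12`, which gives 290 nM, lies within the scatter. That one step, a 1.6-fold higher number from compound 1 to compound 2 (0.21 log units; within the scatter), altered the amine end of the chain and did not move the number meaningfully. Compound 3 `CNCCOc1cccc2ccccc12` differs from compound 2 by methylamino in place of 2-(dimethylamino)ethyl on a saturated chain carbon, two bonds along the chain from an oxygen on an aromatic ring. Among the compounds with values here, only that single step bears on this change, and it was within the scatter, so no step beyond the scatter is expected. Compound 3 is therefore estimated at 380 nM, within 120 nM to 1200 nM. The expected step is a 1.2-fold lower number from compound 2 to compound 3 (0.09 log units; within the scatter).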

Compound 3, inhibition constant: 26 nM
The estimate for compound 3 lay 15-fold (1.16 log units) above the measured number; the whole stated range lies above it.
By their numbers in this assay, from the lowest: compound 3; then compounds 1 and 2 (each within the scatter of the next).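

Changes at the amine end of the chain are not always as small as the step between compound 1 and compound 2 suggested. In this assay, methylamino in place of 2-(dimethylamino)ethyl gives an 18-fold lower number from compound 2 to compound 3 (1.26 log units; beyond the scatter) and methylamino in place of aminomethyl gives an 11-fold lower number from compound 1 to compound 3 (1.05 log units; beyond the scatter), so this saturated chain carbon, two bonds along the chain from an oxygen on an aromatic ring, can carry large changes. No measurement shown explains these steps. From the compounds shown here alone, compound 3 alters both the chain and the amine end, so their separate contributions remain open. Going by these compounds, how ethylamino or pyrrolidine would behave here is also open.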